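From isopropyl to methyl: compound 3 to compound 4

A few compounds are considered here, and "the series" means these few. Any claim that something is new, unique, unknown or untested is made for them only; others in the source may bear on it.

In a functional assay on HeLa cells (Homo sapiens) for cytotoxicity, read by MTT assay (a higher number here means a weaker inhibitor, a lower number a stronger inhibitor), compound 1 `CC(C)C[C@@H](NC(=S)Nc1ccccc1)c1nc2ccccc2[nH]1` gives 12100 nM as its half-maximal inhibitory concentration and compound 2 `CC(C)[C@@H](NC(=S)NCc1ccccc1)c1nc2ccccc2[nH]1` gives 12300 nM in the same read-out. These two values lie within the usual scatter of each other. Among the compounds with values here, compound 3 `CC(C)[C@@H](NC(=S)Nc1ccccc1)c1nc2ccccc2[nH]1` is recorded as "not active" (no number reported) with no number reported, so it has no place on the numeric scale and no measured step links it to compound 1 or compound 2.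

Compound 4 `C[C@@H](NC(=S)Nc1ccccc1)c1nc2ccccc2[nH]1` differs from compound 3 in one group. The change is methyl in place of isopropyl on a saturated chain carbon bound to an amide-type nitrogen and an aromatic carbon and amounts to methyl in place of isopropyl on a saturated chain carbon bound to an amide-type nitrogen and an aromatic carbon.

Within the data shown here, no measured step speaks to this change, and without a number for compound 3 its size cannot be read from the data. The expectation in this assay is a modest one: compound 4 should stay weak, with any reported number somewhat higher than that of compound 1. Compound 1 serves as the reference here at 12100 nM. A report without a number, as for compound 3, is also expected to be a real possibility. Compound 4 is estimated at 30000 nM with an expected range from 12000 nM to 100000 nM in this read-out.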

Compound 4, half-maximal inhibitory concentration: 12400 nM
Beside the measured number, compound 4's estimate is 2.4-fold (0.38 log units) above it, within the range that was stated.
By their numbers in this assay, from the lowest: compounds 1, 2 and 4 (each within the scatter of the next).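

In this assay the step of a 1.0-fold higher number from compound 1 to compound 4 (0.01 log units; within the scatter) puts hydrogen in place of isopropyl on a saturated chain carbon, two bonds along the chain from an amide-type nitrogen and an aromatic carbon, and the two numbers stand within the scatter of each other. With methyl in place of isopropyl on the saturated chain carbon bound to an amide-type nitrogen and an aromatic carbon, compound 4 gives 12400 nM, a number on the scale where compound 3 is recorded only as not active, so the change from compound 3 to compound 4 has no size that can be read. No measurement at hand bears on the reason for these readings.

From the compounds shown here alone, whether an ethyl group, a cyclopropyl ring, a primary amine or a carboxylic acid at this saturated chain carbon would give a number in this assay stays open. Going by these compounds, compound 2 also carries isopropyl and gives 12300 nM, so it remains open whether the record for compound 3 depends on isopropyl alone or on isopropyl together with the rest of its structure.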